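The compounds below may be only part of what the source reports. "The series", "measured", "known", "first", "only" and "open" are said of these compounds alone.

Among the compounds with values here, in a functional assay on K562 cells (Homo sapiens) for inhibition, read by trypan blue exclusion, with a stated time of 72 h (a higher number here means a weaker inhibitor, a lower number a stronger inhibitor), compound 3 `Cn1c(=O)c(S(=O)(=O)c2ccc(F)cc2)cc2cnc(Nc3ccc4[nH]ccc4c3)nc21` gives 200 nM, the lowest of the three numbers so far. Compound 1 `Cn1c(=O)c(S(=O)(=O)c2ccc(F)cc2)cc2cnc(Nc3ccc4cc[nH]c4c3)nc21` gives 10000 nM, and compound 2 `Cn1c(=O)c(S(=O)(=O)c2ccc(F)cc2F)cc2cnc(Nc3ccc4[nH]ncc4c3)nc21` gives 50000 nM. The unmeasured compound 4 `Cn1c(=O)c(S(=O)(=O)c2ccc(F)cc2)cc2cnc(Nc3ccc4[nH]ncc4c3)nc21` differs from compound 3 in one group: 1H-indazol-5-yl in place of 1H-indol-5-yl on a nitrogen on an aromatic ring. In short, 1H-indazol-5-yl stands in place of 1H-indol-5-yl on a nitrogen on an aromatic ring. Within the data shown here, the one measured step at this place is a 50-fold lower number from compound 1 to compound 3 (1.70 log units; beyond the scatter), a large step in which 1H-indol-5-yl replaced 1H-indol-6-yl, so the numbers in this assay can move far with a change in this group. Compound 2, at 50000 nM, carries the same 1H-indazol-5-yl group, but it also differs from compound 4 elsewhere and is only a loose guide. A clear rise in the number, beyond the scatter, is therefore expected, a 10-fold higher number from compound 3 to compound 4 (1.00 log units; beyond the scatter). For compound 4 the estimated value is 2000 nM, with an expected range of 300 nM to 20000 nM.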

Compound 4, half-maximal inhibitory concentration: 10000 nM
For compound 4 the middle estimate is 5.0-fold (0.70 log units) below the measured one, within the range that was stated.
By their numbers in this assay, from the lowest: compound 3; then compounds 1 and 4 (each within the scatter of the next); then compound 2.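

In this assay the swap of 1H-indol-5-yl for 1H-indazol-5-yl (a 50-fold higher number from compound 3 to compound 4 (1.70 log units; beyond the scatter)) shows that this position responds to a change of atoms within the five-membered aromatic ring, and not only to the change of attachment seen earlier. The step between the two other groups (no change at the digits printed from compound 1 to compound 4 (within the scatter)) leaves 1H-indol-5-yl alone among the three at this nitrogen, while hydrogen in place of fluoro on an aromatic carbon (a 5.0-fold lower number from compound 2 to compound 4 (0.70 log units; beyond the scatter)) shows that a change elsewhere on the molecule also registers, as a modest step. Nothing given here explains these steps. As far as these compounds go, whether a 1-methylindol-5-yl or a 1H-benzimidazol-5-yl group would stay near compound 3 200 nM remains open. So does whether the fluoro step would have the same size with 1H-indol-5-yl in place.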